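A few compounds are considered here, and "the series" means these few. Any claim that something is new, unique, unknown or untested is made for them only; others in the source may bear on it.

Measured so far:
compound 1 `Cc1nnc(SCC(=O)N/N=c2/scc(-c3ccc(Cl)cc3)n2-c2ccccc2)s1`: 253 ug/mL
compound 2 `Cc1ccc(-c2cs/c(=N/NC(=O)CSc3nncn3C)n2-c2ccccc2)cc1`: 130 ug/mL
compound 3 `COc1ccc(-c2cs/c(=N/NC(=O)CSc3nnc(C)s3)n2-c2ccccc2)cc1`: 300 ug/mL

In an ADME assay on NIH3T3 cells (Mus musculus) for cytotoxicity, read by MTT assay, with a stated time of 24 h (on this read-out higher numbers stand for weaker inhibition and lower numbers for stronger inhibition), compound 3 gives the highest of the three numbers; the step of a 1.2-fold higher number from compound 1 to compound 3 (0.07 log units; within the scatter) is within the scatter, while compound 2 lies further off. Compound 4 `COc1ccc(-c2cs/c(=N/NC(=O)CSc3nncn3C)n2-c2ccccc2)cc1` differs from compound 3 by 4-methyl-4H-1,2,4-triazol-3-yl in place of 5-methyl-1,3,4-thiadiazol-2-yl on a sulfur. Among the compounds with values here, no measured pair differs in this place alone. Compound 1 and compound 2 differ here and also on the aromatic carbon; compound 1 gives 253 ug/mL where compound 2 gives 130 ug/mL. That pair points toward a lower number, but the two changes cannot be separated. The expected step in this assay is a 2.0-fold lower number from compound 3 to compound 4 (0.30 log units; within the scatter), toward a lower number. Compound 4 is estimated at 150 ug/mL, with a range of 80 ug/mL to 290 ug/mL.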

Compound 4, half-maximal inhibitory concentration: 167 ug/mL
For compound 4 the middle estimate is 1.1-fold (0.05 log units) below the measured one, within the range that was stated.
By their numbers in this assay, from the lowest: compounds 2, 4, 1 and 3 (each within the scatter of the next, the first and the last beyond it).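

In this assay, the change on the sulfur can now be read alone, with the methoxy kept: a 1.8-fold lower number from compound 3 to compound 4 (0.25 log units; within the scatter) shows that 4-methyl-4H-1,2,4-triazol-3-yl and 5-methyl-1,3,4-thiadiazol-2-yl are not told apart here. With 4-methyl-4H-1,2,4-triazol-3-yl kept, a 1.3-fold higher number from compound 2 to compound 4 (0.11 log units; within the scatter) adds that the change on the aromatic carbon is not resolved either. Nothing available explains these results. Open, as far as these compounds go, is whether an amine or a carboxylic acid in place of these rings on the sulfur would give a step beyond the scatter.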